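Swapping Benzyloxy for Bromo on a Shared Core

The source may hold more compounds than are shown below. What is called first, only, known or untested is meant among the compounds shown, and "the series" means these compounds.

Of the compounds shown here, two have been measured so far in a functional assay on A549 cells (Homo sapiens) for inhibition, tested at 0.1 uM; a lower number here means a weaker effect, a higher number a stronger effect of the compound at the concentration tested. Compound 1 `Cc1ccc(S(=O)(=O)n2cc(-c3cc(C(F)(F)F)ccn3)c3ccccc32)cc1` gives 25% in this assay. Compound 2 `Cc1ccc(S(=O)(=O)n2cc(-c3cc(C(F)(F)F)ccn3)c3cc(OCc4ccccc4)ccc32)cc1` gives 16.9%, and this lies within the usual scatter of the number for compound 1, so neither can be called stronger or weaker. Going by the values given here, the only measured step, a number 8.1 percentage points lower from compound 1 to compound 2 (within the scatter), stayed within the scatter.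

Compound 3 `Cc1ccc(S(=O)(=O)n2cc(-c3cc(C(F)(F)F)ccn3)c3cc(Br)ccc32)cc1` is not yet measured. It differs from compound 2 at that same carbon: bromo in place of benzyloxy on an aromatic carbon. Among the compounds with values here, the one step that bears on this position is the one just described, and no step beyond the scatter is expected because a number 8.1 percentage points lower from compound 1 to compound 2 (within the scatter) was itself within the scatter. The step expected here is a number 4.1 percentage points higher from compound 2 to compound 3 (within the scatter). Compound 3 is therefore estimated to give about 21%, most likely between 8% and 34%.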

Compound 3, a percentage reported as inhibition, at one concentration (the size of the read-out at that concentration, not a potency): 38.9%
For compound 3 the middle estimate is 17.9 percentage points below the measured one, and the stated range ends below it.
By their numbers in this assay, from the lowest: compounds 2 and 1 (each within the scatter of the next); then compound 3.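

The earlier step at this carbon stayed within the scatter, so it could not show whether the position responds to a change at all; the new compound shows that it does. In this assay, bromo in place of benzyloxy gives a number 22 percentage points higher from compound 2 to compound 3 (beyond the scatter), and bromo in place of hydrogen gives a number 13.9 percentage points higher from compound 1 to compound 3 (beyond the scatter), so compound 3 stands clear of both neighbours, which lie within the scatter of each other. Nothing available explains why bromo stands apart from hydrogen and benzyloxy here.

Going by these compounds alone, with only three groups at this carbon, it remains open whether the higher number is particular to bromo or would also appear with chloro, fluoro, methoxy or an amine. On these data alone, each number also comes from a single concentration, so how these compounds would compare in potency remains open.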